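The compounds below may be only part of what the source reports. "The series", "measured", "known", "first", "only" and "open" are said of these compounds alone.

Measured in a functional assay on Malme-3M cells (Homo sapiens) for antiproliferative activity, with a stated time of 48 h; on this read-out lower numbers stand for higher toxicity in this test and higher numbers for lower toxicity in this test:

compound 1 `Cc1cc(O)c(C2=NN(c3ccc(S(N)(=O)=O)cc3)C(c3ccccc3O)C2)cc1Cl` – 59200 nM
compound 2 `Cc1cc(O)c(C2=NN(c3ccc(S(N)(=O)=O)cc3)C(c3ccccc3Cl)C2)cc1Cl` – the value for compound 2 is a limit of the assay, > 100000 nM
compound 3 `Cc1cc(O)c(C2=NN(c3ccc(S(N)(=O)=O)cc3)C(/C=C/c3ccccc3)C2)cc1Cl` – 51900 nM

Compound 3 gives the lowest of the two numbers in this assay, with compound 1 nearest, the two lying within the scatter of each other; the third value shown is a limit.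

Compound 4 `COc1ccc(C2CC(c3cc(Cl)c(C)cc3O)=NN2c2ccc(S(N)(=O)=O)cc2)cc1OC` differs from compound 3 only at the saturated ring carbon: 3,4-dimethoxyphenyl in place of 2-phenylethenyl on a saturated ring carbon. The two measured steps at this same position are a 1.1-fold lower number from compound 1 to compound 3 (0.06 log units; within the scatter) and an at least 1.9-fold lower number from compound 2 to compound 3 (0.28 log units; that floor lies within the scatter), neither of which reaches beyond the scatter. Going by the values given here, the only other measured step, an at least 1.6-fold higher number from compound 1 to compound 2 (0.22 log units; that floor lies within the scatter), is likewise a limit within the scatter, and with the limit of > 100000 nM in this assay, at which 1 of the 3 values shown sits, it sets one of the three values as a floor only. Exchanges of the aryl or alkenyl group at this carbon have so far moved the read-out little, so no step beyond the scatter is expected here either.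

Compound 4 is therefore estimated at 55000 nM, with a range from 25000 nM to 120000 nM, that estimate meaning a 1.1-fold higher number from compound 3 to compound 4 (0.03 log units; within the scatter).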

Compound 4, concentration lethal to 50% of the cells: > 100000 nM
Compound 4: only a limit was reported (the forecaster's own chance of this, stated with the estimate: 25%); middle value at least 1.8-fold (0.25 log units) from the limit.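

In this assay, as far as these compounds go, the change to 3,4-dimethoxyphenyl on the saturated ring carbon gives an at least 1.9-fold higher number from compound 3 to compound 4 (0.28 log units; that floor lies within the scatter) and an at least 1.6-fold higher number from compound 1 to compound 4 (0.22 log units; that floor lies within the scatter); both are floors, so the real size of each step is unknown. Unlike the earlier exchanges, this one shows that a second aryl group besides 2-chlorophenyl, here with two methoxy groups, also ends at a limit, leaving only compound 1 and compound 3 with readable numbers at this position. The step between compound 2 and compound 4 cannot be read, as both values are limits: the limit of > 100000 nM in this assay, at which 2 of the 4 values shown sit.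

From the compounds shown here alone, whether any exchange at this carbon moves the read-out beyond the scatter remains open. Also open, going by these compounds, is how an amine, a carboxylic acid or a longer alkyl chain at this carbon would read.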